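Removing a Methyl from the Methoxy of Compound 3

The source may hold more compounds than are shown below. What is called first, only, known or untested is meant among the compounds shown, and "the series" means these compounds.

Compound 3 `COc1cc(-c2nn(-c3cccc(NC(=O)Nc4ccc(Cl)c(Cl)c4)c3)cc2-c2ccncc2)ccc1Cl` carries a (3,4-dichlorophenyl)amino group on its carbonyl carbon and a methoxy group on the 4-chloro-3-methoxyphenyl ring. In a functional assay on UACC-257 cells (Homo sapiens) for inhibition, read by sulforhodamine B assay, with a stated time of 48 h (a higher number here means that more compound is tolerated, a lower number that less compound is tolerated), compound 3 gives only a limit of the assay, > 50000 nM. Its neighbours are equally silent. Compound 2 `COc1cc(-c2nn(-c3cccc(NC(=O)c4cccc(C(F)(F)F)c4)c3)cc2-c2ccncc2)ccc1Cl` keeps the same methoxy ring but bears a 3-(trifluoromethyl)phenyl group on the carbonyl carbon. In this assay compound 2 also gives only a limit, > 50000 nM. The step that the two limits leave unreadable from compound 2 to compound 3 is therefore not readable. Compound 1 `O=C(Nc1cccc(-n2cc(-c3ccncc3)c(-c3ccc(Cl)c(O)c3)n2)c1)Nc1cccc(C(F)(F)F)c1` already has the hydroxy in place of the methoxy, with a urea to a trifluoromethylphenyl ring. In this assay compound 1 likewise gives only a limit, > 32500 nM. Compound 4 `O=C(Nc1cccc(-n2cc(-c3ccncc3)c(-c3ccc(Cl)c(O)c3)n2)c1)Nc1ccc(Cl)c(Cl)c1` differs from compound 3 by hydrogen in place of methyl on an oxygen on an aromatic ring, that is, methoxy to hydroxy. Among the compounds with values here, no measured step bears on this change with a readable size; the three values shown are the limits the limit of > 32500 nM in this assay, at which 1 of the 3 values shown sits, and (the limit of > 50000 nM in this assay, at which 2 of the 3 values shown sit). Compound 4 is thus expected to stay at the limit, an expected step of an at least 1.1-fold lower number from compound 3 to compound 4 (0.04 log units; that floor lies within the scatter) meaning no change beyond the scatter. The estimate for compound 4 is 45000 nM, between 12000 nM and 150000 nM.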

Compound 4, concentration lethal to 50% of the cells: > 32500 nM
Compound 4: no number, only a limit (the forecaster's own chance of this, stated with the estimate: 80%); the middle value does not contradict the limit.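

Within the data shown here, compound 1, compound 3 and compound 4 all give only limits of the assay, so neither the step from compound 3 to compound 4 nor the one from compound 1 to compound 4 can be read. The compounds shown leave open whether hydroxy in place of methoxy has any effect in this assay.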